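Sulfonyl aryl swap in a chalcone-like growth inhibitor series

The compounds below may be only part of what the source reports. "The series", "measured", "known", "first", "only" and "open" are said of these compounds alone.

Three compounds of this series carry measurements in a functional assay on DU-145 cells (Homo sapiens) for inhibition, read by trypan blue exclusion, with a stated time of 96 h; a higher number here means a weaker inhibitor of growth, a lower number a stronger inhibitor of growth. Compound 1 `O=C(/C(=C\c1ccccc1F)S(=O)(=O)c1ccc(Br)cc1)c1ccc(Cl)cc1` gives 25000 nM there, compound 2 `Cc1ccc(S(=O)(=O)/C(=C/c2ccccc2F)C(=O)c2ccc(Cl)cc2)cc1` gives 2500 nM, and compound 3 `CCOc1ccc(/C=C(\C(=O)c2ccc(Br)cc2)S(=O)(=O)c2ccc(C)cc2)cc1OC` gives 1000 nM, the lowest of the three numbers. Compound 2 and compound 1 differ by bromo in place of methyl on an aromatic carbon and the step is a 10-fold higher number from compound 2 to compound 1 (1.00 log units; beyond the scatter). Compound 3 and compound 2 share the sulfonyl and enone arrangement but differ elsewhere in more than one place, and that difference between the two cores is not broken down here.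

Compound 4 `CCOc1ccc(/C=C(\C(=O)c2ccc(Br)cc2)S(=O)(=O)c2ccc(Br)cc2)cc1OC` has not yet been measured. It differs from compound 3 by bromo in place of methyl on an aromatic carbon, the same change as from compound 2 to compound 1, made on the same kind of place. Because the earlier step was a 10-fold higher number from compound 2 to compound 1 (1.00 log units; beyond the scatter), the expectation for compound 4 is a step of about the same size from compound 3, a 10-fold higher number from compound 3 to compound 4 (1.00 log units; beyond the scatter) in this assay. Among the measured compounds shown here, the middle estimate for compound 4 is 10000 nM, with the likely range set by 3000 nM and 30000 nM, since only one prior example of the change is at hand.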

Compound 4, concentration for 50% growth inhibition: 1000 nM
The estimate for compound 4 lay 10-fold (1.00 log units) above the measured number, outside the stated range (below it).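

In this assay, replacing 4-methylphenyl with 4-bromophenyl on the sulfonyl group gives no change at the digits printed from compound 3 to compound 4 (within the scatter), so the large step seen on the core of compound 2 does not carry over to the core of compound 3: the same change on two cores in this assay, a 10-fold higher number (1.00 log units; beyond the scatter) from compound 2 to compound 1 and no change at the digits printed (within the scatter) from compound 3 to compound 4, 10-fold (1.00 log units) apart, beyond the scatter of two such steps In these two pairs the outcome of this change depends on the core, and a step read on one core is a poor guide to the other. The two cores differ in more than one place, so these compounds do not show which of those differences goes with the gap, and two pairs give no rule for any further core.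

From the compounds shown here alone, it remains open whether a third core would behave like the pair of compound 2 and compound 1 or like the pair of compound 3 and compound 4. Also open, going by these compounds, is how the core of compound 3 responds to a group of another kind at the same place, such as an amine or a carboxylic acid in place of the methyl.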